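Nitro for cyano on the sulfonyl ring of a pyrazoline

The source may report more compounds than this note shows. Statements on the series, on what has been measured and on what is new or still open speak of the compounds shown alone.

Compound 2 `CN(C)c1ccc(C2CC(c3ccc(-n4ccnc4)cc3)=NN2S(=O)(=O)c2ccc(C#N)cc2)cc1` was tested in a functional assay on MDA-MB-231 cells (Homo sapiens) for inhibition, read by sulforhodamine B assay, tested at 10 uM (a lower number here means less inhibition, a higher number more inhibition at the concentration tested (going by the name of the read-out)), where compound 2 gives 7.1%. Its nearest relative among the measured compounds is compound 1 `COC(=O)CC(=O)N1N=C(c2ccc(-n3ccnc3)cc2)CC1c1ccc(N(C)C)cc1`, for which compound 1 gives 2.3%; the step of a number 4.8 percentage points higher from compound 1 to compound 2 (within the scatter) places the two within the scatter of each other, so neither stands apart.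

Compound 3 `CN(C)c1ccc(C2CC(c3ccc(-n4ccnc4)cc3)=NN2S(=O)(=O)c2ccc([N+](=O)[O-])cc2)cc1` has not been measured. It differs from compound 2 by nitro in place of cyano on an aromatic carbon. Among the compounds with values here, no measured step changes the group on the aryl ring of the sulfonyl substituent, so nothing in the data speaks directly to this exchange. Within the data shown here, both measured compounds sit near the bottom of the scale, and the only step available lies within the scatter. Compound 3 is therefore expected to remain in the same low region, with the step of a number 0.9 percentage points higher from compound 2 to compound 3 (within the scatter) estimated to stay within the scatter. For compound 3 the estimate is 8%, in a range from -4% to 22%.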

Compound 3, a percentage reported as inhibition, at one concentration (the size of the read-out at that concentration, not a potency): 41.5%
Compound 3: middle estimate off by 33.5 percentage points, on the low side, outside the stated range (above it).
By their numbers in this assay, from the lowest: compounds 1 and 2 (each within the scatter of the next); then compound 3.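

In this assay, the group on the aryl ring of the sulfonyl substituent proves able to move the read-out: nitro in place of cyano gives a number 34.4 percentage points higher from compound 2 to compound 3 (beyond the scatter). Replacing ((methoxycarbonyl)methyl)carbonyl on the ring nitrogen gives a number 39.2 percentage points higher from compound 1 to compound 3 (beyond the scatter) with (4-nitrophenyl)sulfonyl, whereas (4-cyanophenyl)sulfonyl gave only a number 4.8 percentage points higher from compound 1 to compound 2 (within the scatter), so a sulfonyl group there does not by itself separate these compounds. Nothing available explains why nitro and cyano differ in this way.

The compounds shown leave open whether an amine, a carboxylic acid or a methoxy group in the same place on that aryl ring would give a similarly large number, or whether the step is particular to nitro. As the read-out comes from a single concentration, they also leave the potency of compound 3 open.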